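The compounds below may be only part of what the source reports. "The series", "measured", "known", "first", "only" and "open" are said of these compounds alone.

Among the measured compounds shown here, compound 2 `Cn1cc(-c2cnc3c(-c4csc(C(=O)N[C@@H]5CCC[C@H]5N)c4)cnn3c2)cn1` is the stronger of the two compounds measured so far in an assay for inhibition of MAP/microtubule affinity-regulating kinase 3 (Homo sapiens), read by HTRF, with a stated time of 2 h; on this read-out lower numbers stand for stronger inhibition and higher numbers for weaker inhibition: compound 2 gives 3 nM, whereas compound 1 `Cn1cc(-c2cnc3c(-c4csc(C(=O)N[C@@H]5CCC[C@H]5O)c4)cnn3c2)cn1` gives 10 nM. For the measured compounds named here, these two structures differ in one place only, and that step, a 3.3-fold lower number from compound 1 to compound 2 (0.52 log units; beyond the scatter), is the sole measured comparison available here. Compound 3 `Cn1cc(-c2cnc3c(-c4csc(C(=O)N[C@@H]5CCCC[C@H]5O)c4)cnn3c2)cn1` now differs from compound 2 by a group of 7 heavy atoms (6 carbon, 1 oxygen; one six-membered non-aromatic ring of carbon only) in place of a group of 6 heavy atoms (5 carbon, 1 nitrogen; one five-membered non-aromatic ring of carbon only), on an amide-type nitrogen. Going by the values given here, this change swaps the amino group back for a hydroxy group, the reverse of what separated compound 1 from compound 2, but it also changes the size of the saturated ring, for which no measured step exists. The reversal of the amino-for-hydroxy change is therefore expected to carry most weight, pointing toward a modest rise in the number, with added uncertainty from the ring change. Because compound 1 with its hydroxy group gives 10 nM, compound 3 is expected to land close to that figure, at an estimated 10 nM with a range of 3 nM to 35 nM. The expected step is a 3.3-fold higher number from compound 2 to compound 3 (0.52 log units; beyond the scatter).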

Compound 3, half-maximal inhibitory concentration: 24 nM
Beside the measured number, compound 3's estimate is 2.4-fold (0.38 log units) below it; the measured number falls inside the stated range.
By their numbers in this assay, from the lowest: compound 2; then compound 1; then compound 3.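

With the hydroxy group kept, 2-hydroxycyclohexyl in place of 2-hydroxycyclopentyl on the amide-type nitrogen gives a 2.4-fold higher number from compound 1 to compound 3 (0.38 log units; beyond the scatter), so ring size at this position matters in its own right, something the earlier pair could not show, since both of its members carry a five-membered ring. The wider replacement gives an 8.0-fold higher number from compound 2 to compound 3 (0.90 log units; beyond the scatter), but that step takes in both the larger ring and the change from amino to hydroxy, and only the comparison with compound 1 lets the ring change be read apart from the rest. Nothing at hand explains why the six-membered ring gives the higher number, and the direction of this one step is all that can be stated.

Still open, from the compounds shown here alone, is whether 2-aminocyclohexyl on the same nitrogen would gain from the amino group as the five-membered ring did, which would show whether the amino and ring effects act independently of each other. Also open, going by these compounds, is how the trend continues with 2-hydroxycycloheptyl, a larger ring, or with 2-hydroxyethyl, an open chain with no ring at all.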